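Swapping a Pyridyl for Phenyl on a Shared Biaryl Core

The compounds below may be only part of what the source reports. "The series", "measured", "known", "first", "only" and "open" are said of these compounds alone.

Measured compounds:
Compound 1 `Oc1cccc(-c2cc(-c3ccncc3)nc(-c3ccccc3Cl)c2)c1` – "not determined" (no result reported)
Compound 2 `Oc1cccc(-c2cc(-c3cccc(Cl)c3)nc(-c3ccccn3)c2)c1` – "not determined" (no result reported)
Compound 3 `Oc1ccc(-c2cc(-c3cccs3)nc(-c3ccccc3Cl)c2)cc1` – 5220 nM

Compound 1 `Oc1cccc(-c2cc(-c3ccncc3)nc(-c3ccccc3Cl)c2)c1` stands without a number in an ADME assay on HEK293 cells (Homo sapiens) for cytotoxicity, read by CCK-8 assay and cell counting, with a stated time of 2 days; a lower number here means a stronger inhibitor, a higher number a weaker inhibitor: for compound 1 the entry reads "not determined" (no result reported). The same is true of compound 2 `Oc1cccc(-c2cc(-c3cccc(Cl)c3)nc(-c3ccccn3)c2)c1`, for which the entry reads "not determined" (no result reported). The only figure in this assay comes from compound 3 `Oc1ccc(-c2cc(-c3cccs3)nc(-c3ccccc3Cl)c2)cc1`, which gives 5220 nM and shares the 2-chlorophenyl group with compound 1 while differing from it elsewhere.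

Compound 4 `Oc1cccc(-c2cc(-c3ccccc3)nc(-c3ccccc3Cl)c2)c1` is not yet measured. It differs from compound 1 in one place: phenyl in place of pyridin-4-yl on an aromatic carbon. For the measured compounds named here, no step between measured compounds exists that could anchor the size of this change, and compound 1 itself has no value, so nothing in the data says how large a shift in this assay to expect, in either direction, or whether it would stay within the scatter at all.

With compound 3 as the sole reference point in this assay, the estimate for compound 4 rests on that single value and on the similarity of its core to compound 3. Compound 4 is expected to give about 6000 nM, with a range from 2000 nM to 20000 nM.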

Compound 4, half-maximal inhibitory concentration: 1760 nM
The estimate for compound 4 lay 3.4-fold (0.53 log units) above the measured number, and the stated range ends above it.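

Compound 4 gives 1760 nM in this assay, but no step can be read from this result, as the entry for compound 1 reads "not determined" (no result reported). The compounds shown leave open how far pyridin-4-yl and phenyl differ in this read-out at that place on the shared core. Nothing available here bears on the result.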